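A few compounds are considered here, and "the series" means these few. Any claim that something is new, unique, unknown or untested is made for them only; others in the source may bear on it.

Compound 1 `CC(=O)OC[C@H]1O[C@@H](n2cc(Cn3cc(/C=C/C(=O)c4cccnc4)c4ccccc43)nn2)[C@H](OC(C)=O)[C@@H](OC(C)=O)[C@@H]1OC(C)=O` gave only a limit in an ADME assay on NIH3T3 cells (Homo sapiens) for cytotoxicity, read by sulforhodamine B assay, with a stated time of 48 h (a lower number here means a stronger inhibitor, a higher number a weaker inhibitor), > 200000 nM.
Compound 2 `CC(=O)OC[C@H]1O[C@@H](n2cc(CN3C(=O)/C(=C/c4ccccc4)c4ccccc43)nn2)[C@H](OC(C)=O)[C@@H](OC(C)=O)[C@@H]1OC(C)=O` gave only a limit in this assay, > 100000 nM.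
Compound 3 `CC(=O)OC[C@H]1O[C@@H](n2cc(CN3C(=O)/C(=C\c4ccc(C)cc4)c4ccccc43)nn2)[C@H](OC(C)=O)[C@@H](OC(C)=O)[C@@H]1OC(C)=O` gave a number in this assay, 9000 nM.

Compound 3 therefore stands as the only one of the three with a measured number; the other two are limits. Compound 1 sits at the limit of > 200000 nM in this assay, at which 1 of the 3 values shown sits. Compound 2 sits at the limit of > 100000 nM in this assay, at which 1 of the 3 values shown sits. Compound 4 `CC(=O)OC[C@H]1O[C@@H](n2cc(CN3C(=O)/C(=C\c4cccs4)c4ccccc43)nn2)[C@H](OC(C)=O)[C@@H](OC(C)=O)[C@@H]1OC(C)=O` has not yet been measured; it differs from compound 3 by thiophen-2-yl in place of 4-methylphenyl on a double-bonded chain carbon bound to a double-bonded ring carbon. For the measured compounds named here, no step between measured compounds is available for this change, so any expectation rests on compound 3 alone. The exchange of one aromatic ring for another of similar size is expected to give at most a modest step, a 1.3-fold higher number from compound 3 to compound 4 (0.12 log units; within the scatter), possibly not beyond the scatter. Compound 4 is estimated at 12000 nM, within 3000 nM to 60000 nM.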

Compound 4, half-maximal inhibitory concentration: 14600 nM
Compound 4: middle estimate off by 1.2-fold (0.09 log units), on the low side; the range from low to high includes it.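

For the compounds shown here, at this position, on a double-bonded chain carbon bound to a double-bonded ring carbon, thiophen-2-yl in place of 4-methylphenyl gives the only step that can be read in this assay: a 1.6-fold higher number from compound 3 to compound 4 (0.21 log units; within the scatter). A five-membered aromatic ring with 1 hetero atom can therefore stand in for a six-membered aromatic ring of carbon only here, with no change that can be told from the scatter. Nothing shown gives a cause for this step. Going by these compounds, whether an amine or a carboxylic acid at this place would move the number remains open.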